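The source may hold more compounds than are shown below. What is called first, only, known or untested is meant among the compounds shown, and "the series" means these compounds.

Working notes on the amide series. Compound 1 `COc1ccccc1C(=O)Nc1cccc(-c2oc3cc(-c4ccc(F)cc4)ccc3c(=O)c2O)c1` and compound 2 `O=C(Nc1cccc(-c2oc3cc(-c4ccc(F)cc4)ccc3c(=O)c2O)c1)c1ccc(Br)cc1` share the same core and differ only in the aryl group on the carbonyl carbon. In a functional assay on A549 cells (Homo sapiens) for antiproliferative activity, read by CCK-8 assay, with a stated time of 72 h (on this read-out higher numbers stand for weaker inhibition and lower numbers for stronger inhibition), compound 1 gives 11700 nM, and in this assay compound 2 gives 13500 nM. Among the compounds with values here, compound 2 thus stands beside compound 1 as one of two numbers so far, and a 1.2-fold higher number from compound 1 to compound 2 (0.06 log units; within the scatter), so the two cannot be separated.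

Compound 3 `Cc1cccc(C(=O)Nc2cccc(-c3oc4cc(-c5ccc(F)cc5)ccc4c(=O)c3O)c2)c1` is the next member: 3-methylphenyl in place of 4-bromophenyl on a carbonyl carbon. Within the data shown here, the only measured step that bears on this place is the exchange of one aryl group for another on the same carbonyl carbon, which gave a 1.2-fold higher number from compound 1 to compound 2 (0.06 log units; within the scatter). By that precedent, a further aryl exchange at this position is expected to move the number little, and the estimated step is a 1.0-fold lower number from compound 2 to compound 3 (0.02 log units; within the scatter), with no direction beyond the scatter.

The estimate for compound 3 in this assay is 13000 nM, expected to lie between 6000 nM and 28000 nM.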

Compound 3, half-maximal inhibitory concentration: 16500 nM
Compound 3: middle estimate off by 1.3-fold (0.10 log units), on the low side, and the stated range covers the measured number.
By their numbers in this assay, from the lowest: compounds 1, 2 and 3 (each within the scatter of the next).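

Replacing 4-bromophenyl with 3-methylphenyl on the carbonyl carbon gives a 1.2-fold higher number from compound 2 to compound 3 (0.09 log units; within the scatter) and replacing 2-methoxyphenyl with 3-methylphenyl gives a 1.4-fold higher number from compound 1 to compound 3 (0.15 log units; within the scatter) in this assay and neither step separates the compounds. With a third aryl group, all three pairs now lie within the scatter, so 2-methoxyphenyl, 4-bromophenyl and 3-methylphenyl cannot be told apart at this position. The exchange of 4-bromophenyl for 3-methylphenyl also replaces a bromine-bearing aryl group with an all-carbon one of the same heavy-atom count, without a resolved change in the number, and no supporting measurement is available to interpret this result.

Every group shown on this carbonyl carbon is a substituted phenyl ring, so the range of the position remains untested by these compounds. Going by these compounds, what an amine, a carboxylic acid or a longer alkyl chain would do in place of the aryl group remains open.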